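This account rests on a few compounds, and the source may have more. Where it says the series, first, only, none or still open, it means among the compounds named here.

In a functional assay on SMMC-7721 cells (Homo sapiens) for inhibition, read by MTT assay, with a stated time of 48 h (on this read-out lower numbers stand for stronger inhibition and higher numbers for weaker inhibition), compound 1 (`CN(c1ncccc1CNc1nc(Nc2ccc3c(c2)CC(=O)N3)nc2[nH]cc(F)c12)S(C)(=O)=O`) gives 73200 nM and compound 2 (`COc1ccc(Nc2nc(NCc3cccnc3N(C)S(C)(=O)=O)c3c(F)c[nH]c3n2)cc1OC`) gives 54800 nM on the same read-out. Compound 3 (`COc1cc(Nc2nc(NCc3cccnc3N(C)S(C)(=O)=O)c3c(F)c[nH]c3n2)cc(OC)c1OC`) stands at > 100000 nM as a limit of the assay and not a number. Compound 4 (`CN(c1ncccc1CNc1nc(Nc2cccc(CN)c2)nc2[nH]cc(F)c12)S(C)(=O)=O`) carries a different group on a nitrogen on an aromatic ring (3-(aminomethyl)phenyl in place of 3,4,5-trimethoxyphenyl on a nitrogen on an aromatic ring), with 3-(aminomethyl)phenyl in place of 3,4,5-trimethoxyphenyl. Three other swaps at that place bear on this change: a 1.3-fold lower number from compound 1 to compound 2 (0.13 log units; within the scatter) and an at least 1.8-fold higher number from compound 2 to compound 3 (0.26 log units; that floor lies within the scatter) and an at least 1.3-fold higher number from compound 1 to compound 3 (0.13 log units; that floor lies within the scatter) all stay within the scatter, the last two as floors only. No step beyond the scatter is therefore expected in this assay for this swap. The expected step is an at least 1.6-fold lower number from compound 3 to compound 4 (0.22 log units; that floor lies within the scatter) and it rests on those floors. Compound 4 is estimated at 60000 nM with 20000 nM to 100000 nM as the expected range.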

Compound 4, half-maximal inhibitory concentration: > 100000 nM
Compound 4: no number, only a limit; the forecaster's own chance of this, stated with the estimate: 30%; middle value at least 1.6-fold (0.22 log units) away from the limit.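

In this assay compound 4 stands at a limit of the assay and not a number, and so does compound 3: the limit of > 100000 nM in this assay, at which 2 of the 4 values shown sit. Putting 3-(aminomethyl)phenyl on this nitrogen brings no measurable gain, with an at least 1.8-fold higher number from compound 2 to compound 4 (0.26 log units; that floor lies within the scatter) and an at least 1.3-fold higher number from compound 1 to compound 4 (0.13 log units; that floor lies within the scatter). The step between compound 3 and compound 4 cannot be read, as both values are limits.

On these data alone, what a carboxylic acid or a longer amine chain at this place would give stays open. So does whether any group on this nitrogen can reach a far lower number.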